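Working notes: chloro in place of bromo, compound 4

The source may hold more compounds than are shown below. What is called first, only, known or untested is meant among the compounds shown, and "the series" means these compounds.

Values so far in a functional assay (Homo sapiens) for antiproliferative activity, read by sulforhodamine B assay, with a stated time of 48 h (on this read-out higher numbers stand for weaker inhibition and lower numbers for stronger inhibition), are these
- compound 1 `O=C1NCCN1c1ccc(S(=O)(=O)Nc2ccc3[nH]ccc3c2)cc1` gives 770 nM here
- compound 2 `COc1cc(NS(=O)(=O)c2ccc(N3CCNC3=O)cc2)cc(OC)c1OC` gives 58 nM here
- compound 3 `O=C1NCCN1c1ccc(S(=O)(=O)Nc2cccc(Br)c2)cc1` gives 270 nM here

Among these three, compound 3 at 270 nM holds the middle place in this assay, with a higher number than compound 2 and a lower number than compound 1. Both gaps lie beyond the usual scatter.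

The next compound to be measured is compound 4 `O=C1NCCN1c1ccc(S(=O)(=O)Nc2cccc(Cl)c2)cc1` and it differs from compound 3 in one place only chloro in place of bromo on an aromatic carbon with chloro in place of bromo on an aromatic carbon, meta to a large group. Within the data shown here, no two measured compounds differ in a single place, so the series gives no direct measure of a swap of this kind. The expectation therefore rests on the smallness of the change alone, and no direction is favoured. An estimated step of a 1.1-fold higher number from compound 3 to compound 4 (0.05 log units; within the scatter) is expected in this assay and should stay within the scatter. For compound 4 the expected value is 300 nM with an estimated range from 130 nM to 700 nM in the same read-out.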

Compound 4, half-maximal inhibitory concentration: 190 nM
Beside the measured number, compound 4's estimate is 1.6-fold (0.20 log units) above it; the range from low to high includes it.
By their numbers in this assay, from the lowest: compound 2; then compounds 4 and 3 (each within the scatter of the next); then compound 1.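

Among these compounds, the only single-place comparison reads in this assay as a 1.4-fold lower number from compound 3 to compound 4 (0.15 log units; within the scatter) and gives the first direct measure of a swap at this position. On this aromatic carbon, meta to a large group, bromo and chloro cannot be told apart on this read-out, so the activity of compound 3 does not depend on bromo specifically. No available data explain this result or tie it to any property of either group.

Still open, from the compounds shown here alone, is whether this position accepts groups of another kind, such as an amine, a carboxylic acid or a methoxy group, and what plain hydrogen at this place would give. Also open, going by these compounds, is whether the same swap would behave alike at other places on the ring.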